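Dimethylphenyl Amide Variant of a Benzothiazole Antiproliferative Series

A few compounds are considered here, and "the series" means these few. Any claim that something is new, unique, unknown or untested is made for them only; others in the source may bear on it.

Compound 1, `O=C(CSc1cccc(O)c1)Nc1ccc2nc(NC(=O)c3cc(Cl)cc(Cl)c3)sc2c1`: 5440 nM
Compound 2, `Cc1cc(C)cc(C(=O)Nc2nc3ccc(NC(=O)CSc4ccc(Cl)cc4)cc3s2)c1`: 65100 nM
Compound 3, `O=C(CSc1cccc(O)c1)Nc1ccc2nc(NC(=O)c3ccc(F)cc3)sc2c1`: 6170 nM

In a functional assay on HCT-116 cells (Homo sapiens) for antiproliferative activity, read by MTT assay, with a stated time of 72 h (a lower number here means a stronger inhibitor, a higher number a weaker inhibitor), compound 3 gives 6170 nM. Among the three measured compounds compound 3 holds the second highest number; compound 1, at 5440 nM, sits within the scatter of it, while compound 2, at 65100 nM, lies far above it and beyond the scatter.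

Compound 4, `Cc1cc(C)cc(C(=O)Nc2nc3ccc(NC(=O)CSc4cccc(O)c4)cc3s2)c1`, differs from compound 3 by 3,5-dimethylphenyl in place of 4-fluorophenyl on a carbonyl carbon. Within the data shown here, one measured step touches the same carbonyl carbon: a 1.1-fold higher number from compound 1 to compound 3 (0.05 log units; within the scatter). That step left the number essentially unchanged, so an aryl swap at this position need not move this assay much. Compound 2 carries the same 3,5-dimethylphenyl as compound 4 but a different thioether aryl, and its value is the highest of the three; its comparison with compound 4 is not a single listed step, so only the two values can be weighed. Taken together, compound 4 is expected to give 12000 nM (range 4000 nM to 50000 nM), with the expected step of a 1.9-fold higher number from compound 3 to compound 4 (0.29 log units; within the scatter) leaning toward a weaker inhibitor but within broad uncertainty.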

Compound 4, half-maximal inhibitory concentration: 5130 nM
Beside the measured number, compound 4's estimate is 2.3-fold (0.37 log units) above it; low and high end bracket the measured number.
By their numbers in this assay, from the lowest: compounds 4, 1 and 3 (each within the scatter of the next); then compound 2.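

In this assay the position on the carbonyl carbon now holds a third aryl group with no readable effect: a 1.2-fold lower number from compound 3 to compound 4 (0.08 log units; within the scatter) and a 1.1-fold lower number from compound 1 to compound 4 (0.03 log units; within the scatter) both sit within the scatter, so 4-fluorophenyl, 3,5-dichlorophenyl and 3,5-dimethylphenyl cannot be told apart while the sulfur carries 3-hydroxyphenyl. The large difference lies at the sulfur instead, where a 13-fold lower number from compound 2 to compound 4 (1.10 log units; beyond the scatter) shows, with 3,5-dimethylphenyl held fixed on the carbonyl carbon, that the high number of compound 2 goes with its 4-chlorophenyl rather than with its amide aryl group. Nothing measured here accounts for this contrast in step size and the difference remains only an observation.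

Going by these compounds, it remains open whether an amine or a carboxylic acid on the carbonyl-bound phenyl ring would leave the number equally unmoved. Also open, on these data alone, is whether the sulfur step holds with other carbonyl groups, or with a longer alkyl chain on the sulfur.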